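The compounds below may be only part of what the source reports. "The series", "measured", "known", "first", "only" and "open" are said of these compounds alone.

Working notes on the series, read in a functional assay on DU-145 cells (Homo sapiens) for inhibition, read by trypan blue exclusion, with a stated time of 96 h; a higher number here means a weaker inhibitor of growth, a lower number a stronger inhibitor of growth. Compound 1 (`Cc1ccc(CS/C(=C/c2c(O)cc(O)cc2O)C(=O)c2ccc(Cl)cc2)cc1`) gives 50000 nM. Compound 2 (`COc1ccc(C(=O)/C(=C\c2ccc(OC)c(O)c2)Sc2ccc(F)cc2)cc1`) gives 1000 nM, the lower of the two numbers, and its gap to compound 1 lies beyond the scatter. Compound 3 (`COc1ccc(C(=O)/C(=C\c2ccc(Br)cc2)Sc2ccc(F)cc2)cc1`) has not yet been measured. Its difference from compound 2 is 4-bromophenyl in place of 3-hydroxy-4-methoxyphenyl on a double-bonded chain carbon bound to a double-bonded chain carbon, with 4-bromophenyl in place of 3-hydroxy-4-methoxyphenyl on a double-bonded chain carbon bound to a double-bonded chain carbon. Going by the values given here, no step between measured compounds isolates this change, and the two measured compounds differ in more than one place, so the data offer no direct guide. A moderate move towards a higher number, meaning weaker growth inhibition, is expected, and the estimated step is a 4.0-fold higher number from compound 2 to compound 3 (0.60 log units; beyond the scatter). For compound 3 the expected value is 4000 nM, with an estimated range of 800 nM to 20000 nM.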

Compound 3, concentration for 50% growth inhibition: > 100000 nM
Compound 3: only a limit was reported (the forecaster's own chance of this, stated with the estimate: 10%); at least 25-fold (1.39 log units) between middle value and limit.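

In this assay, going by these compounds alone, 4-bromophenyl in place of 3-hydroxy-4-methoxyphenyl on a double-bonded chain carbon bound to a double-bonded chain carbon gives an at least 100-fold higher number from compound 2 to compound 3 (2.00 log units; beyond the scatter), the first step that isolates a single place. This position is therefore not indifferent to its group, and the growth inhibition seen with compound 2 does not carry over to the 4-bromophenyl compound. Compound 3 gives a limit, not a number, so the step has a lower bound but no known full size: the limit of > 100000 nM in this assay, at which 1 of the 3 values shown sits.

The change removes the hydroxy and methoxy groups and adds the bromine in one move, so the compounds shown do not tell which of these carries the step. A 3-hydroxyphenyl, a 4-methoxyphenyl or an unsubstituted phenyl group at this place would separate those contributions.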